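Cyano series: 3-hydroxypropyl in place of cyclopentyl

The compounds below may be only part of what the source reports. "The series", "measured", "known", "first", "only" and "open" are said of these compounds alone.

In a functional assay on KB cells (Homo sapiens) for antiproliferative activity, read by sulforhodamine B assay, with a stated time of 48 h (on this read-out lower numbers stand for stronger inhibition of growth and higher numbers for weaker inhibition of growth), compound 2 `N#Cc1ccc(Nc2nc(NC3CCCC3)c3ccccc3n2)cc1` gives only a limit and not a number, > 31300 nM.

Compound 3 `Nc1ccc(Nc2nc(NC3CCCC3)c3ccccc3n2)cc1` carries amino in place of cyano and gives 17400 nM. The measured step reads an at least 1.7-fold lower number from compound 2 to compound 3 (0.25 log units; that floor lies within the scatter). That step concerns the other end of the molecule and does not touch the group changed here.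

Compound 4 `N#Cc1ccc(Nc2nc(NCCCO)c3ccccc3n2)cc1` keeps the cyano group of compound 2 and changes the amine substituent, with 3-hydroxypropyl in place of cyclopentyl on a nitrogen on an aromatic ring.

For the measured compounds named here, no measured step isolates this change. The nearest evidence is compound 1 `COc1ccc(Nc2nc(NCCCO)c3ccccc3n2)cc1`, which already carries the (3-hydroxypropyl)amino group alongside a methoxy group in place of cyano and gives 20300 nM. With that value and with compound 3 at 17400 nM, all three measured compounds sit in the same weak region of this assay, and nothing in the series points to a large gain from the new chain.

The expected outcome is therefore no step beyond the scatter, and a further limit in place of a number remains quite possible. The expected step is an at least 1.2-fold lower number from compound 2 to compound 4 (0.08 log units; that floor lies within the scatter).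

For compound 4 the estimate is 26000 nM, with an expected range of 13000 nM to 45000 nM.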

Compound 4, concentration for 50% growth inhibition: 23700 nM
For compound 4 the middle estimate is 1.1-fold (0.04 log units) above the measured one; measured number inside the range.
By their numbers in this assay, from the lowest: compounds 3, 1 and 4 (each within the scatter of the next). At a limit, above all of these: compound 2.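

Going by these compounds, the step at this nitrogen reads an at least 1.3-fold lower number from compound 2 to compound 4 (0.12 log units; that floor lies within the scatter), so in this assay 3-hydroxypropyl in place of cyclopentyl gives the cyano series its first number, but the true size of the change stays unknown and no gain beyond the scatter can be claimed. Compound 2 gives a limit and not a number, and the step has only a floor because of that limit: the limit of > 31300 nM in this assay, at which 1 of the 4 values shown sits.

For the compounds shown here, with the (3-hydroxypropyl)amino group held constant, the step reads a 1.2-fold higher number from compound 1 to compound 4 (0.07 log units; within the scatter), which gives the first comparison of cyano and methoxy on an aromatic carbon and shows no difference beyond the scatter on this chain.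

The compounds shown leave open whether the loss of the cyclopentyl ring or the entry of the hydroxy group counts for more in this swap, as the two changes arrive together. Also open, on these data alone, is how a plain propyl chain, a longer 4-hydroxybutyl chain or an amine-bearing chain would read on this nitrogen, and how the (3-hydroxypropyl)amino group would read with amino in place of cyano.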